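Swapping an ester end for an ether end at the limit

The compounds below may be only part of what the source reports. "The series", "measured", "known", "first", "only" and "open" are said of these compounds alone.

In an ADME assay on L929 cells (Mus musculus) for cytotoxicity, read by resazurin assay, with a stated time of 48 h (on this read-out lower numbers stand for higher toxicity in this test and higher numbers for lower toxicity in this test), compound 1 (`O=c1c2cc([N+](=O)[O-])ccc2n(CCCBr)n1Cc1ccccc1`) gives 25200 nM as its reading. Compound 2 (`O=C(O)CCn1c2ccc([N+](=O)[O-])cc2c(=O)n1Cc1ccccc1`) gives > 256000 nM as a limit of the assay and not a number. Compound 3 (`COC(=O)CCOc1c2cc([N+](=O)[O-])ccc2nn1Cc1ccccc1`) gives > 256000 nM as a limit and not a number too. The data so far are thus capped by the limit of > 256000 nM in this assay, at which 2 of the 3 values shown sit, and compound 3 sits at that limit, with no true number of its own.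

Compound 4 (`COCCOc1c2cc([N+](=O)[O-])ccc2nn1Cc1ccccc1`) differs from compound 3 by methoxy in place of methoxycarbonyl on a saturated chain carbon, two bonds along the chain from an oxygen on an aromatic ring and so carries a 2-methoxyethoxy chain where compound 3 has a 2-(methoxycarbonyl)ethoxy chain. Going by the values given here, the one measured step is an at least 10-fold higher number from compound 1 to compound 2 (1.00 log units; beyond the scatter) and it bears only loosely on this change. It swaps other groups, on a chain starting from an aromatic nitrogen rather than an oxygen.

The best guide is therefore the limit > 256000 nM of compound 3, and no step beyond the scatter is expected in this assay from it. By this estimate the expected change is an at least 1.2-fold lower number from compound 3 to compound 4 (0.10 log units; that floor lies within the scatter) and no larger. For compound 4 the expected value is 200000 nM with an estimated range from 80000 nM to 256000 nM and the reading may well be only a limit again.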

Compound 4, concentration lethal to 50% of the cells: > 256000 nM
Compound 4: a limit, no number; the forecaster's own chance of this, stated with the estimate: 55%; middle value at least 1.2-fold (0.10 log units) away from the limit.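

Going by these compounds alone, compound 3 and compound 4 both read as limits and not as numbers, so no step between them can be read in this assay: the limit of > 256000 nM in this assay, at which 3 of the 4 values shown sit.

The compounds shown leave open whether the 2-methoxyethoxy chain of compound 4 and the 2-(methoxycarbonyl)ethoxy chain of compound 3 differ at all in this test, and if so, by how much.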